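The source may hold more compounds than are shown below. What is called first, only, known or untested is meant among the compounds shown, and "the series" means these compounds.

Of the compounds shown here, two have been measured in a physicochemical assay for solubility, read by chemiluminescence, measured as kinetic solubility (a lower number here means a less soluble compound, a higher number a more soluble compound), and neither yields an exact number. Compound 1 (`CC(=O)NCc1cccc(Cn2nc(NS(=O)(=O)c3ccc(Cl)s3)c3c(C#N)cccc32)c1`) is reported as >= 155 ug/mL, which is a limit and not a number. Compound 2 (`COc1cccc2c1c(NS(=O)(=O)c1ccc(Cl)s1)nn2Cc1cccc(CNC(=O)C2CCCO2)c1`) is also reported only as a limit, >= 153 ug/mL. The account now follows the step from compound 2 to compound 3 (`COc1cccc2c1c(NS(=O)(=O)c1ccc(Cl)s1)nn2Cc1cccc(CNC(=O)[C@@H]2CCCCN2)c1`). The shared core and the rest of the molecule stay the same, while piperidin-2-yl takes the place of oxolan-2-yl on a carbonyl carbon whose other neighbour is an amide-type nitrogen: piperidin-2-yl in place of oxolan-2-yl on a carbonyl carbon. Among the measured compounds shown here, no measured step between two compounds that differ in one place is available as a guide, so the expectation rests on the limit of >= 153 ug/mL held by compound 2. No change beyond the usual scatter is expected in this assay, and the estimated at least 1.0-fold lower number from compound 2 to compound 3 (0.00 log units; that floor lies within the scatter) has no clear direction. The reading may well again be only a limit. For compound 3 the expected value is 150 ug/mL, with an estimated range of 90 ug/mL to 165 ug/mL.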

Compound 3, solubility: >= 220 ug/mL
Compound 3: no number, only a limit; the forecaster's own chance of this, stated with the estimate: 65%; at least 1.4-fold (0.16 log units) between middle value and limit.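

In this assay, compound 2 and compound 3 are both reported only as limits, and no step can be read between them. The compounds shown leave open where the true value of each lies, and whether piperidin-2-yl in place of oxolan-2-yl on a carbonyl carbon changes the read-out at all.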